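This account rests on a few compounds, and the source may have more. Where it says the series, first, only, none or still open, it means among the compounds named here.

Measured so far:
compound 1 `Cc1cccc(S(=O)(=O)Nc2cccc(/C=C/C(=O)c3nc4ccccc4[nH]3)c2)c1`, 597 nM
compound 2 `Cc1ccc(S(=O)(=O)Nc2cccc(/C=C/C(=O)c3nc4ccccc4[nH]3)c2)cc1`, 1990 nM

Going by the values given here, in a functional assay on HCT-116 cells (Homo sapiens) for antiproliferative activity, read by MTT assay, with a stated time of 48 h (on this read-out lower numbers stand for stronger inhibition and higher numbers for weaker inhibition), compound 2 stands highest of the two numbers; its nearest neighbour is compound 1, and the only step in hand runs from there: a 3.3-fold higher number from compound 1 to compound 2 (0.52 log units; beyond the scatter). Compound 3 `O=C(/C=C/c1cccc(NS(=O)(=O)c2cc(Cl)cc(Cl)c2)c1)c1nc2ccccc2[nH]1` is not yet measured. It differs from compound 2 in one place: 3,5-dichlorophenyl in place of 4-methylphenyl on a sulfonyl sulfur. Among the compounds with values here, no measured step carries a chlorine or a 3,5-disubstituted ring, so the one step that bears on it is the 1 to 2 step, which shows the number rising with 4-methylphenyl in place of 3-methylphenyl. Going back to a ring carrying substituents in the 3- and 5-positions, the step from compound 2 to compound 3 is expected to be downward, a 2.5-fold lower number from compound 2 to compound 3 (0.40 log units; beyond the scatter), though with wide uncertainty. Compound 3 is therefore estimated at 800 nM, with a range of 250 nM to 2500 nM.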

Compound 3, half-maximal inhibitory concentration: 2840 nM
For compound 3 the middle estimate is 3.6-fold (0.55 log units) below the measured one, and the stated range ends below it.
By their numbers in this assay, from the lowest: compound 1; then compounds 2 and 3 (each within the scatter of the next).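

In this assay the exchange of 4-methylphenyl for 3,5-dichlorophenyl on the sulfonyl sulfur gives a 1.4-fold higher number from compound 2 to compound 3 (0.15 log units; within the scatter) and leaves the two groups not separable at this position. Going by these compounds alone, compound 1 remains apart from both others, with a 3.3-fold higher number from compound 1 to compound 2 (0.52 log units; beyond the scatter) and a 4.8-fold higher number from compound 1 to compound 3 (0.68 log units; beyond the scatter) both beyond the scatter, so 3-methylphenyl is the only one of the three groups that stands out, and 3,5-dichlorophenyl in compound 3 does not share that result. Nothing available accounts for this difference.

Still open, going by these compounds, is whether the result of compound 1 belongs to methyl itself or extends to other single groups on that ring, such as 3-chlorophenyl or 3-methoxyphenyl. Also open, on these data alone, is where unsubstituted phenyl, or a ring carrying an amine or a carboxylic acid, would fall relative to these three compounds.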